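A few compounds are considered here, and "the series" means these few. Any claim that something is new, unique, unknown or untested is made for them only; others in the source may bear on it.

Measured compounds:
compound 1 `O=C(Nc1cc(C(F)(F)F)cc(C(F)(F)F)c1)c1ccccc1O`: > 100000 nM
compound 2 `O=C(Nc1cc(C(F)(F)F)cc(C(F)(F)F)c1)c1cccc(Cl)c1O`: 12000 nM
compound 3 `O=C(Nc1cc(Cl)cc(Cl)c1)c1cc(Cl)ccc1O`: 19000 nM

The three measured compounds share an amide linking a substituted phenol to a substituted aniline, and all were tested in an assay for inhibition of transmembrane protease serine 4 (Homo sapiens), read by fluorescence; on this read-out lower numbers stand for stronger inhibition and higher numbers for weaker inhibition. Compound 1 gives a value that is only a limit of the assay, > 100000 nM, and so no number is known for it; this is the situation described by the limit of > 100000 nM in this assay, at which 1 of the 3 values shown sits. Compound 2 differs from compound 1 by chloro in place of hydrogen on an aromatic carbon, and that change brings an at least 8.3-fold lower number from compound 1 to compound 2 (0.92 log units; beyond the scatter). Compound 3 gives 19000 nM. How the core of compound 3 differs from the core of compound 1 is not broken down here. Compound 3 stands nearest to compound 2, and the two values lie within the scatter of each other.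

Compound 4 `O=C(Nc1cc(Cl)c(Cl)c(Cl)c1)c1cc(Cl)ccc1O` is not yet measured. It differs from compound 3 by chloro in place of hydrogen on an aromatic carbon. For the measured compounds named here, this is the same kind of change as the one from compound 1 to compound 2, but not the same change: there the chloro entered ortho to a hydroxy group and meta to a large group, whereas here it enters ortho to two chloro groups and para to a large group. Given the size of an at least 8.3-fold lower number from compound 1 to compound 2 (0.92 log units; beyond the scatter), a smaller step is expected for compound 4 in this assay, estimated at a 2.4-fold lower number from compound 3 to compound 4 (0.38 log units; beyond the scatter), since the earlier step sits on the other ring and starts from a limit rather than a number. The value for compound 4 is therefore estimated at 8000 nM, with a range from 2000 nM to 40000 nM.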

Compound 4, half-maximal inhibitory concentration: > 100000 nM
Compound 4 ended at the assay's limit; the forecaster's own chance of this, stated with the estimate: 10%; middle value at least 12-fold (1.09 log units) from the limit.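

In this assay compound 4 gives > 100000 nM, which is a limit of the assay and not a number. Chloro in place of hydrogen on an aromatic carbon, here ortho to two chloro groups and para to a large group, brings an at least 5.2-fold higher number from compound 3 to compound 4 (0.72 log units; beyond the scatter), so within this series the change does not carry over from one core to the other with the same direction of effect: the same change on two cores in this assay, an at least 8.3-fold lower number (0.92 log units; beyond the scatter) from compound 1 to compound 2 and an at least 5.2-fold higher number (0.72 log units; beyond the scatter) from compound 3 to compound 4, at least 43-fold (1.64 log units) apart, beyond the scatter of two such steps This does not show whether the core itself or the place where the chloro enters decides the outcome, since the two steps differ in both, and each rests on a single pair of compounds, with both sizes remaining bounds tied to one limit: the limit of > 100000 nM in this assay, at which 2 of the 4 values shown sit.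

The compounds shown leave open what chloro would do at the matching place on the core of compound 1, and what it would do at the place it occupies in compound 2 on the core of compound 3, either of which would separate the role of the core from the role of the place. Also open, on these data alone, is whether a smaller fluoro group, an amine or a carboxylic acid at the place where chloro entered in compound 4 would keep a measurable number in this assay.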